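Sulfonyl aryl swap carried onto a hydroxyphenyl core

This account rests on a few compounds, and the source may have more. Where it says the series, first, only, none or still open, it means among the compounds named here.

Measured compounds:
compound 1, `COc1cc(-c2nc(-c3ccccc3)[nH]c2-c2ccnc(NCCCNS(=O)(=O)c3cccc(F)c3)n2)ccc1F`, giving 900 nM in a functional assay on LOX IMVI cells (Homo sapiens) for cytotoxicity, read by MTT assay, with a stated time of 24 h; a higher number here means a weaker inhibitor, a lower number a stronger inhibitor
compound 2, `COc1cc(-c2nc(-c3ccccc3)[nH]c2-c2ccnc(NCCCNS(=O)(=O)c3ccc(C)cc3)n2)ccc1F`, giving 2590 nM in this assay
compound 3, `O=S(=O)(NCCCNc1nccc(-c2[nH]c(-c3ccccc3)nc2-c2ccc(F)c(O)c2)n1)c1cccc(F)c1`, giving 7890 nM in this assay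

Of the compounds shown here, three have been measured in this assay; a fourth, compound 4 `Cc1ccc(S(=O)(=O)NCCCNc2nccc(-c3[nH]c(-c4ccccc4)nc3-c3ccc(F)c(O)c3)n2)cc1`, has not. Compound 3 carries the highest of the three numbers, and its steps to each of the other two lie beyond the scatter. Compound 1 and compound 3 differ in the core by hydrogen in place of methyl on an oxygen on an aromatic ring, and that change produced an 8.8-fold higher number from compound 1 to compound 3 (0.94 log units; beyond the scatter). Compound 1 and compound 2 differ by 4-methylphenyl in place of 3-fluorophenyl on a sulfonyl sulfur, which gave a 2.9-fold higher number from compound 1 to compound 2 (0.46 log units; beyond the scatter). Compound 3 and compound 4 differ by 4-methylphenyl in place of 3-fluorophenyl on a sulfonyl sulfur. The place is the same word for word in both pairs, a sulfonyl sulfur whose other neighbour is a sulfonamide nitrogen, so this is the same change set on a different core. Among the compounds with values here, only one earlier instance of it exists, and it lies beyond the scatter, so compound 4 is expected to show an upward step of similar size, a 2.5-fold higher number from compound 3 to compound 4 (0.40 log units; beyond the scatter), because a 2.9-fold higher number from compound 1 to compound 2 (0.46 log units; beyond the scatter) is the only guide available. Compound 4 is therefore estimated at 20000 nM, with a range from 8000 nM to 50000 nM.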

Compound 4, half-maximal inhibitory concentration: 26300 nM
Estimate against measurement, compound 4: 1.3-fold (0.12 log units) below; the range from low to high includes it.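

In this assay, putting 4-methylphenyl in place of 3-fluorophenyl on a sulfonyl sulfur gave a 3.3-fold higher number from compound 3 to compound 4 (0.52 log units; beyond the scatter), and the step carried over from the methyl-bearing core at much the same size: the same change on two cores in this assay, a 2.9-fold higher number (0.46 log units; beyond the scatter) from compound 1 to compound 2 and a 3.3-fold higher number (0.52 log units; beyond the scatter) from compound 3 to compound 4, 1.2-fold (0.06 log units) apart, within the scatter of two such steps. Hydrogen in place of methyl on an oxygen on an aromatic ring gave a 10-fold higher number from compound 2 to compound 4 (1.01 log units; beyond the scatter), so in these compounds that change also kept its size when the sulfonyl aryl group differed: the same change on two cores in this assay, an 8.8-fold higher number (0.94 log units; beyond the scatter) from compound 1 to compound 3 and a 10-fold higher number (1.01 log units; beyond the scatter) from compound 2 to compound 4, 1.2-fold (0.06 log units) apart, within the scatter of two such steps. This set of four compounds in one cell assay shows that the two changes added up here, but it does not show that either would keep its size on any other core, and it does not explain why either change raises the number.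

The compounds shown leave open how other groups on the sulfonyl sulfur, such as a pyridine ring or a 4-methoxyphenyl, would behave on either core. They also leave open whether an ethyl ether on the oxygen or a longer chain in place of the present one would follow the same steps.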